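Loss of the methoxy group in a hydroxamic acid sulfonamide

The compounds below may be only part of what the source reports. "The series", "measured", "known", "first", "only" and "open" are said of these compounds alone.

Measured compounds:
compound 1 `CC(C)CN(Cc1ccc(C(=O)NO)cc1)S(=O)(=O)c1cc(F)c(F)c(F)c1F` gives > 1000 nM
compound 2 `COc1cc(C(=O)NO)ccc1CN(C(C)C)S(=O)(=O)c1cc(F)c(F)c(F)c1F` gives 474 nM

Of the compounds shown here, two have been tested in an assay on Sf9 cells for inhibition of histone deacetylase 8 (Homo sapiens), read by fluorescence and mobility shift assay; on this read-out higher numbers stand for weaker inhibition and lower numbers for stronger inhibition. Compound 1 `CC(C)CN(Cc1ccc(C(=O)NO)cc1)S(=O)(=O)c1cc(F)c(F)c(F)c1F` returns only a limit, > 1000 nM, so no number is known for it. Going by the values given here, compound 2 `COc1cc(C(=O)NO)ccc1CN(C(C)C)S(=O)(=O)c1cc(F)c(F)c(F)c1F` is the only compound with a number in this assay, 474 nM. The one other result, that of compound 1, is a limit (the limit of > 1000 nM in this assay, at which 1 of the 2 values shown sits).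

Compound 3 `CC(C)N(Cc1ccc(C(=O)NO)cc1)S(=O)(=O)c1cc(F)c(F)c(F)c1F` has not yet been measured. It differs from compound 2 by hydrogen in place of methoxy on an aromatic carbon. Among the compounds with values here, no measured pair separates this change on its own, so its size is not known from the data. Compound 1, which also lacks the methoxy group, sits at the limit of this assay. On that basis the step is expected to weaken inhibition beyond the scatter, a 1.9-fold higher number from compound 2 to compound 3 (0.28 log units; within the scatter). Compound 3 is therefore estimated at 900 nM, with a range from 350 nM to 2500 nM.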

Compound 3, half-maximal inhibitory concentration: > 1000 nM
Compound 3 gave a limit, no number (the forecaster's own chance of this, stated with the estimate: 40%); middle value at least 1.1-fold (0.04 log units) from the limit.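

Compound 3 gives > 1000 nM in this assay, which is a limit and not a number. Going by these compounds alone, this is the first pair to isolate the methoxy group on this aromatic carbon, ortho to a large group and meta to a hydroxycarbamoyl group, and replacing it with hydrogen gives an at least 2.1-fold higher number from compound 2 to compound 3 (0.32 log units; beyond the scatter), so inhibition at this level depends on the methoxy group in the isopropyl series. The step between isobutyl in compound 1 and isopropyl in compound 3 on the sulfonamide nitrogen cannot be read, as both compounds now rest at one limit: the limit of > 1000 nM in this assay, at which 2 of the 3 values shown sit.

Going by these compounds, how far inhibition falls without the methoxy group remains open, as does the effect of adding it to the isobutyl compound 1. On these data alone, whether ethoxy, hydroxyl or fluorine on this aromatic carbon would match methoxy also remains unknown.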